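Fluoro for Methoxy on the Aryl Ring of Compound 2

A few compounds are considered here, and "the series" means these few. Any claim that something is new, unique, unknown or untested is made for them only; others in the source may bear on it.

Compound 2 `COc1ccc(OC)c(N2C(=O)CSC2c2cccc(C(=O)NCCCCc3ccccc3)c2)c1` stands second highest of the three compounds measured in a functional assay on SJSA-1 cells (Homo sapiens) for inhibition, read by CCK-8 assay, with a stated time of 72 h, tested at 1 uM (a higher number here means more inhibition at the concentration tested (going by the name of the read-out), a lower number less inhibition), where compound 2 gives 48%. Its nearest neighbour is compound 1 `COc1ccc(C)cc1N1C(=O)CSC1c1cccc(C(=O)NCCCCc2ccccc2)c1`, which in this assay gives 79%; the furthest is compound 3 `COc1ccccc1N1C(=O)CSC1C(=O)NCCCCc1ccccc1`, which gives 14%. Among the compounds with values here, the one measured step that bears on the change at hand is a number 31 percentage points lower from compound 1 to compound 2 (beyond the scatter), that is, a large drop when methoxy entered in place of methyl on the aromatic carbon in question. Compound 4 `COc1ccc(F)cc1N1C(=O)CSC1c1cccc(C(=O)NCCCCc2ccccc2)c1` carries the change (fluoro in place of methoxy on an aromatic carbon), so the same methoxy now leaves again and a one-heavy-atom fluoro enters. Since the step from compound 1 to compound 2 was beyond the scatter and the present change reverses the entry of that methoxy, an upward step is expected, though fluoro is not methyl and the size is uncertain. The expected step is a number 17 percentage points higher from compound 2 to compound 4 (beyond the scatter). Compound 4 is therefore estimated at 65%, within a range from 45% to 85%.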

Compound 4, a percentage reported as inhibition, at one concentration (the size of the read-out at that concentration, not a potency): 76%
Compound 4: the middle estimate sits 11 percentage points below what was measured; the range from low to high includes it.
By their numbers in this assay, from the lowest: compound 3; then compound 2; then compounds 4 and 1 (each within the scatter of the next).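

In this assay, this place on the ring, para to a methoxy group, now has three substituents to compare: fluoro in place of methoxy gives a number 28 percentage points higher from compound 2 to compound 4 (beyond the scatter), while fluoro in place of methyl gives a number 3 percentage points lower from compound 1 to compound 4 (within the scatter). The earlier drop therefore does not apply to every change at this carbon, since the fluoro and methyl compounds cannot be told apart here and the 2,5-dimethoxyphenyl compound alone stands lower among these three. Nothing shown accounts for why methoxy differs from the other two groups.

As far as these compounds go, whether a chloro, a hydroxyl, an amine or a plain hydrogen at this carbon would match fluoro and methyl or fall with methoxy remains open. Also open, from the compounds shown here alone, is whether a longer alkoxy chain here would lower the inhibition further.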